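A few compounds are considered here, and "the series" means these few. Any claim that something is new, unique, unknown or untested is made for them only; others in the source may bear on it.

Compound 1, `CCCNC1=NS(=O)(=O)c2ccc(Cl)cc2N1`, carries a propylamino group on the shared core. In a functional assay on aorta (Rattus norvegicus) for inhibition (on this read-out lower numbers stand for an effect already at smaller amounts and higher numbers for an effect only at larger amounts of compound), compound 1 gives 73200 nM. Compound 2, `O=S1(=O)N=C(NC2CCC2)Nc2cc(Cl)ccc21`, differs from it by cyclobutyl in place of propyl on an amine nitrogen. For compound 2 this assay reports only a limit, > 300000 nM. The step of an at least 4.0-fold higher number from compound 1 to compound 2 (0.61 log units; beyond the scatter) is therefore given only as a lower bound, since it ends at the limit of > 300000 nM in this assay, at which 2 of the 3 values shown sit.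

Compound 3, `CCCNC1=NS(=O)(=O)c2c(Cl)cccc2N1`, is built from the same atoms as compound 1, but they are joined differently; the difference between the two cores is not broken down here. For compound 3 this assay again reports only a limit, > 300000 nM. Compound 4, `O=S1(=O)N=C(NC2CCC2)Nc2cccc(Cl)c21`, differs from compound 3 by cyclobutyl in place of propyl on an amine nitrogen. The place of the change is described in the same words for both pairs, so it is the same change made on a different core.

Compound 3 already sits at the limit of this assay, and the one measured occurrence of this change, from compound 1 to compound 2, moved the number upward by at least the amount given. Compound 4 is therefore expected to give a step that the limit leaves unreadable from compound 3 to compound 4, which would leave it beyond the range that this assay resolves. The expectation for compound 4 in this assay is 600000 nM, with a range from 300000 nM to 3000000 nM, and most likely the assay will report only a limit for compound 4 as well.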

Compound 4, half-maximal effective concentration: > 30000 nM
Compound 4 ended at the assay's limit; the forecaster's own chance of this, stated with the estimate: 90%; the middle value lies beyond the limit too.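

In this assay, compound 3 and compound 4 are both reported only as limits, so no step can be read between them for cyclobutyl in place of propyl on an amine nitrogen. The compounds shown leave open whether this change moves the number on the core of compound 3 as it did on the core of compound 1, and how far either compound lies past its limit.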